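This account rests on a few compounds, and the source may have more. Where it says the series, first, only, none or still open, it means among the compounds named here.

Compound 1 `CC(=O)N1CCN([C@H]2CC[C@H](Nc3ncnn4ccc([C@H]5CC[C@H](C(N)=O)CC5)c34)CC2)CC1` stands highest of the three compounds measured in a physicochemical assay for lipophilicity, using the shake flask method, at pH 7.4 (a lower number here means a more polar compound, a higher number a more lipophilic compound), at 1.4. Compound 2 `CN(C)[C@H]1CC[C@H](Nc2ncnc3[nH]cc([C@H]4CC[C@H](C(N)=O)CC4)c23)CC1` gives 0 in this assay, and compound 3 `CN(C)[C@H]1CC[C@H](Nc2ncnc3[nH]ccc23)CC1` gives -0.6. Compound 4 `CC(=O)N1CCN([C@H]2CC[C@H](Nc3ncnn4ccc(C5CCOCC5)c34)CC2)CC1` has not yet been measured. It differs from compound 1 in one place, with oxan-4-yl in place of 4-carbamoylcyclohexyl on an aromatic carbon. Going by the values given here, one measured step bears on this change, on a core other than that of compound 1, with hydrogen in place of the same leaving group: a number 0.60 log units lower from compound 2 to compound 3 (beyond the scatter). Oxan-4-yl is not hydrogen, and no measured compound carries it, so that step gives only a rough scale and no direct reading. Among the compounds with values here, with only this modest step to go on, no change beyond the scatter is expected. The expected step is a number 0.20 log units higher from compound 1 to compound 4 (within the scatter). For compound 4 the estimated value is 1.6, with an expected range from 1.1 to 2.1.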

Compound 4, distribution coefficient: 1.6
Compound 4: the middle estimate sits on the measured number at the digits printed; the measured number falls inside the stated range.
By their numbers in this assay, from the lowest: compound 3; then compound 2; then compounds 1 and 4 (each within the scatter of the next).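

In this assay the change gives a number 0.20 log units higher from compound 1 to compound 4 (within the scatter), so on the core of compound 1 these two groups cannot be told apart, although oxan-4-yl has fewer heavy atoms than 4-carbamoylcyclohexyl and no hydrogen-bond donor. The earlier compounds shown here held only a number 0.60 log units lower from compound 2 to compound 3 (beyond the scatter), which replaced the group with hydrogen on another core, whereas this step exchanges one six-membered non-aromatic ring for another at this position. Nothing measured here accounts for how close the two numbers lie. From the compounds shown here alone, it remains open whether a carboxylic acid or a primary amine on the ring at this place would also leave the number within the scatter. Also open, going by these compounds, is whether oxan-4-yl would behave the same way on the core of compound 2.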